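Thiophene sulfonamides on HeLa cells: a dichlorophenyl urea

The compounds below may be only part of what the source reports. "The series", "measured", "known", "first", "only" and "open" are said of these compounds alone.

Compound 3 `COc1ccc(NC(=S)NCCNS(=O)(=O)c2sccc2-c2ccc(C)cc2Oc2ccc(O)c(O)c2)cc1` was tested in a functional assay on HeLa cells (Homo sapiens) for inhibition, read by CCK-8 assay, with a stated time of 48 h; a lower number here means a stronger inhibitor, a higher number a weaker inhibitor. In this assay compound 3 reaches only the limit of the measurement, > 20000 nM. Compound 1 `O=C(Nc1cccc([N+](=O)[O-])c1)N1CCN(S(=O)(=O)c2sccc2-c2ccccc2Oc2ccc(O)c(O)c2)CC1` likewise gives only the limit, > 20000 nM. Compound 2 `CC(C)c1ccc(Oc2ccc(O)c(O)c2)c(-c2ccsc2S(=O)(=O)NCCNC(=S)Nc2ccc([N+](=O)[O-])cc2)c1` also gives only the limit, > 20000 nM. So all three measured compounds sit at the same limit, (the limit of > 20000 nM in this assay, at which 3 of the 3 values shown sit), and no real step between them can be read.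

Compound 4 `Cc1ccc(-c2ccsc2S(=O)(=O)NCCNC(=O)Nc2cc(Cl)cc(Cl)c2)c(Oc2ccc(O)c(O)c2)c1` differs from compound 3 in one place: a group of 11 heavy atoms (7 carbon, 1 nitrogen, 1 oxygen, 2 chlorine; one six-membered aromatic ring of carbon only) in place of a group of 11 heavy atoms (8 carbon, 1 nitrogen, 1 oxygen, 1 sulfur; one six-membered aromatic ring of carbon only), on an amine nitrogen. With every known value at the limit, no step beyond the usual scatter is expected, and compound 4 is estimated at 25000 nM, with a range from 8000 nM to 60000 nM. The expected step that the limit leaves unreadable from compound 3 to compound 4 is essentially none.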

Compound 4, half-maximal inhibitory concentration: 6500 nM
Compound 4: the middle estimate sits 3.8-fold (0.59 log units) above what was measured; measured number outside the range, below it.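

For the compounds shown here, on the amine nitrogen, the (3,5-dichlorophenyl)carbamoyl group gives the first number that can be read in this assay, with an at least 3.0-fold lower number from compound 3 to compound 4 (0.48 log units; beyond the scatter). Going by these compounds alone, this shows that a change at this place can move the read-out, which the earlier compounds could not show. The full size of the step stays unknown, since compound 3 gives only a limit: the limit of > 20000 nM in this assay, at which 3 of the 4 values shown sit.

The leaving and entering groups differ in more than one atom type, so the compounds shown do not tell which part of the change matters. Going by these compounds, whether a pyridine ring in place of the dichlorophenyl ring would keep the step also stays open.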